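The source may hold more compounds than are shown below. What is called first, only, known or untested is meant among the compounds shown, and "the series" means these compounds.

In an ADME assay on L6 cells (Rattus norvegicus) for cytotoxicity, read by resazurin assay, with a stated time of 72 h (a lower number here means a stronger inhibitor, a higher number a weaker inhibitor), compound 1 (`NC1CC2(N3CCCC3)CC(c3ccccc3)C1C(c1ccccc1)C2`) gives 38100 nM and compound 2 (`CN(C)C12CC(OC(=O)CN3CCCC3)C(C(c3ccccc3)C1)C(c1ccccc1)C2`) gives 32700 nM, so the two values lie within the scatter of each other. Compound 3 (`CN1CCN(CC(=O)NC2CC3(N4CCCC4)CC(c4ccccc4)C2C(c2ccccc2)C3)CC1`) has ((4-methylpiperazin-1-yl)methyl)carbonyl in place of hydrogen on an amine nitrogen of compound 1: ((4-methylpiperazin-1-yl)methyl)carbonyl in place of hydrogen on an amine nitrogen. For the measured compounds named here, no measured pair shows this change, so the expectation rests only on these two values. The expected change is a 1.5-fold lower number from compound 1 to compound 3 (0.18 log units; within the scatter), toward a lower number and within the scatter. For compound 3 the estimated value is 25000 nM, with an expected range from 8000 nM to 80000 nM.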

Compound 3, half-maximal inhibitory concentration: 50200 nM
Compound 3: middle estimate off by 2.0-fold (0.30 log units), on the low side; low and high end bracket the measured number.
By their numbers in this assay, from the lowest: compounds 2, 1 and 3 (each within the scatter of the next).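

In this assay, the amine nitrogen of compound 1 now has its first reading: ((4-methylpiperazin-1-yl)methyl)carbonyl in place of hydrogen gives a 1.3-fold higher number from compound 1 to compound 3 (0.12 log units; within the scatter). At this position, therefore, the hydrogen can be replaced by this whole group, six-membered ring included, with the read-out staying within the usual scatter. A single step cannot show whether a simple acetyl group, or a chain ending in a carboxylic acid, on the same nitrogen would behave alike. Nothing available bears on the reason for this result.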